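Bromo for chloro: a small swap on compound 2

This account rests on a few compounds, and the source may have more. Where it says the series, first, only, none or still open, it means among the compounds named here.

- Compound 1 `C=CCCC1COC2(C=CC(=O)C=C2)N(c2ccccc2)C1=O` gives 730 nM
- Compound 2 `O=C1C=CC2(C=C1)OCC(Cc1ccc(Cl)cc1)C(=O)N2c1ccccc1` gives 540 nM

In a functional assay on BV-2 cells (Mus musculus), read by Griess assay, with a stated time of 24 h (a higher number here means a weaker inhibitor, a lower number a stronger inhibitor), compound 2 stands at 540 nM, within the scatter of compound 1 and so not separable from it. Compound 3 `O=C1C=CC2(C=C1)OCC(Cc1ccc(Br)cc1)C(=O)N2c1ccccc1` differs from compound 2 as follows: bromo in place of chloro on an aromatic carbon. This puts bromo in place of chloro on an aromatic carbon. Among the compounds with values here, only one measured step bears on this: a 1.4-fold lower number from compound 1 to compound 2 (0.13 log units; within the scatter). That replacement of allyl by 4-chlorophenyl is a different change, yet it stayed within the scatter, so no step beyond the scatter is expected in this assay. The expected change is a 1.0-fold lower number from compound 2 to compound 3 (0.02 log units; within the scatter). Compound 3 is estimated at 520 nM, with an expected range of 270 nM to 1000 nM.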

Compound 3, half-maximal inhibitory concentration: 1380 nM
Beside the measured number, compound 3's estimate is 2.7-fold (0.42 log units) below it; measured number outside the range, above it.
By their numbers in this assay, from the lowest: compounds 2, 1 and 3 (each within the scatter of the next, the first and the last beyond it).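

In this assay, within the data shown here, this aromatic carbon proves sensitive to the identity of its halogen: bromo in place of chloro gives a 2.6-fold higher number from compound 2 to compound 3 (0.41 log units; beyond the scatter) as a modest change, the only step so far beyond the scatter. Even so, the step of a 1.9-fold higher number from compound 1 to compound 3 (0.28 log units; within the scatter) stays within the scatter, so 4-bromobenzyl and allyl cannot be separated at the position they share. Nothing measured here explains the difference between chloro and bromo. From the compounds shown here alone, whether fluoro, methoxy or an amine on the same aromatic carbon would sit nearer compound 2 or compound 3 remains open.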